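A few compounds are considered here, and "the series" means these few. Any claim that something is new, unique, unknown or untested is made for them only; others in the source may bear on it.

In a functional assay on A549 cells (Homo sapiens) for antiproliferative activity, read by MTT assay, with a stated time of 48 h (a lower number here means a stronger inhibitor, a higher number a weaker inhibitor), compound 3 (`COc1ccc(C(=O)c2ccc3c(c2)C=CC(C)(C)O3)c(NC(=O)CO)c1`) gives 90 nM. That lies within the scatter of compound 2 (`COc1ccc(C(=O)c2ccc(OC)c3c2C=CC(C)(C)O3)c(NC(=O)CO)c1`) at 100 nM, and well under compound 1 (`COc1ccc(C(=O)c2ccc(OC)c3c2C=CC(C)(C)O3)c(NC(=O)CBr)c1`) at 2460 nM. Compound 4 (`CNCC(=O)Nc1cc(OC)ccc1C(=O)c1ccc2c(c1)C=CC(C)(C)O2`) differs from compound 3 at one place: methylamino in place of hydroxy on a saturated chain carbon bound to a carbonyl carbon. In words, it carries methylamino in place of hydroxy on a saturated chain carbon bound to a carbonyl carbon. Going by the values given here, the only measured step at this place is a 25-fold lower number from compound 1 to compound 2 (1.39 log units; beyond the scatter), a large one, so the group there can move the number in this assay. Among the compounds with values here, no methylamino compound has been measured, however, so only a moderate weakening is expected, with the estimated change being a 2.8-fold higher number from compound 3 to compound 4 (0.44 log units; beyond the scatter). For compound 4 the expected value is 250 nM, within an estimated range of 70 nM to 900 nM.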

Compound 4, half-maximal inhibitory concentration: 800 nM
The estimate for compound 4 lay 3.2-fold (0.51 log units) below the measured number; the range from low to high includes it.
By their numbers in this assay, from the lowest: compounds 3 and 2 (each within the scatter of the next); then compound 4; then compound 1.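

In this assay, methylamino in place of hydroxy on a saturated chain carbon bound to a carbonyl carbon gives an 8.9-fold higher number from compound 3 to compound 4 (0.95 log units; beyond the scatter). Going by these compounds alone, the earlier step at this place concerned only bromo and hydroxy, so this is the first reading for a nitrogen group there. The change is also clearly felt even though both groups count one hydrogen-bond donor, one hydrogen-bond acceptor and no net charge. Going by these compounds, whether a plain amine, dimethylamino or a longer chain would fall nearer compound 3 or compound 4 stays open. Nothing available here accounts for the step.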